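One amide substituent changed on compound 2

A few compounds are considered here, and "the series" means these few. Any claim that something is new, unique, unknown or untested is made for them only; others in the source may bear on it.

Compound 1 `CN(C)C(=O)c1cc2cnc(Nc3ccc(N)cn3)nc2n1C1CCCC1` gives -0.6% 
Compound 2 `CN(C)C(=O)c1cc2cnc(Nc3ccc(NC(=O)C4(C(=O)Nc5cccc(O)c5)CC4)cc3)nc2n1C1CCCC1` gives 75.5% 
Compound 3 `Nc1ccc(NC(=O)C2(C(=O)Nc3ccc(F)cc3)CC2)cc1F` gives 26.7% 

All three were tested in a functional assay on NCI-H460 cells (Homo sapiens) for inhibition, read by CCK-8 assay, with a stated time of 72 h, tested at 1 uM (on this read-out higher numbers stand for more inhibition of growth at the one concentration tested and lower numbers for less inhibition of growth), and no two of them differ in only one place. Compound 2 (75.5%) stands highest of the three, beyond the scatter of both compound 3 and compound 1. Compound 4 `CN(C)C(=O)c1cc2cnc(Nc3ccc(NC(=O)C4(C(=O)Nc5ccc(Cl)c(C(F)(F)F)c5)CC4)cc3)nc2n1C1CCCC1` differs from compound 2 in one place, with 4-chloro-3-(trifluoromethyl)phenyl in place of 3-hydroxyphenyl on an amide-type nitrogen. The measured compounds include no such exchange, so the data give no firm direction for it. The estimated a number 3.5 percentage points lower from compound 2 to compound 4 (within the scatter) is expected to stay within the scatter. Compound 4 is estimated to read 72% (45% to 92%).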

Compound 4, percent growth inhibition at one concentration: 2.1%
Compound 4: middle estimate off by 69.9 percentage points, on the high side; measured number below the stated range.
By their numbers in this assay, from the lowest: compounds 1 and 4 (each within the scatter of the next); then compound 3; then compound 2.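

On the amide-type nitrogen, 4-chloro-3-(trifluoromethyl)phenyl in place of 3-hydroxyphenyl gives a number 73.4 percentage points lower from compound 2 to compound 4 (beyond the scatter) in this assay. This single exchange shows that the group at this place can decide whether the growth inhibition seen with compound 2 is kept, even with the rest of the structure unchanged. Nothing shown gives a reason for the drop. From the compounds shown here alone, whether it follows the loss of the hydroxy group or the arrival of chlorine and trifluoromethyl stays open, as does how a plain phenyl or a methoxyphenyl group on the same nitrogen would read.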